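Methylamino for methoxy on the shared core: cytotoxicity

The source may hold more compounds than are shown below. What is called first, only, known or untested is meant among the compounds shown, and "the series" means these compounds.

Compound 1 `COc1nc(Nc2ccc(C#N)c(OCC=C(C)C)c2)nc(OC)n1`, compound 2 `CSc1ncnc(Nc2ccc(C#N)c(OCC=C(C)C)c2)n1` and compound 3 `COc1ccnc(Nc2ccc(Cl)c(OCC=C(C)C)c2)n1` have been run in an ADME assay on MT2 cells (Homo sapiens) for cytotoxicity; a higher number here means that more compound is tolerated, a lower number that less compound is tolerated. For compound 1 the result is a limit of the assay, > 100000 nM, and not a number. That entry is the limit of > 100000 nM in this assay, at which 1 of the 3 values shown sits. Compound 2 gives 8400 nM in this assay. Compound 3 gives 9000 nM in this assay; the two numbers lie within the scatter of each other, so compound 3 stands alongside compound 2.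

Compound 4 `CNc1ccnc(Nc2ccc(Cl)c(OCC=C(C)C)c2)n1` has not yet been measured in this assay. It differs from compound 3 in one place: methylamino in place of methoxy on an aromatic carbon. Within the data shown here, no measured pair shows this change, so its effect in this assay is open; from the sole anchor, compound 3 at 9000 nM, a step of no more than the scatter is expected, in either direction. Compound 4 is expected to give 10000 nM in this assay, within 4000 nM to 25000 nM. The expected step is a 1.1-fold higher number from compound 3 to compound 4 (0.05 log units; within the scatter), not beyond the scatter.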

Compound 4, half-maximal cytotoxic concentration: 690 nM
Estimate against measurement, compound 4: 14-fold (1.16 log units) above, and the stated range ends above it.
By their numbers in this assay, from the lowest: compound 4; then compounds 2 and 3 (each within the scatter of the next). At a limit, above all of these: compound 1.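

In this assay, among these compounds, this position on the shared core proves sensitive, with a 13-fold lower number from compound 3 to compound 4 (1.12 log units; beyond the scatter) for methylamino in place of methoxy on an aromatic carbon, the first single-place change whose size can be read. The two groups match in heavy-atom count and differ in one atom, the nitrogen for the oxygen, which brings one hydrogen-bond donor, so a small exchange here is enough to lower the tolerated concentration markedly. No measured result shown gives a cause for this step.

From the compounds shown here alone, whether the step follows the amine hydrogen or the nitrogen itself remains open, and a dimethylamino group at this position would help separate the two. One pair also leaves open whether the same exchange would act alike on a core carrying the nitrile, as compound 2 does.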